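Replacing the Carboxymethoxy Group with a Saturated Carboxylic Chain

The source may hold more compounds than are shown below. What is called first, only, known or untested is meant among the compounds shown, and "the series" means these compounds.

Compound 3 `O=C(O)COc1ccc(Cn2cccn2)cc1OCCc1ccc2ccccc2c1` gives 2600 nM in an in vitro functional assay on CHO cells for antagonist activity at prostaglandin E2 receptor EP3 subtype (Mus musculus) (a lower number here means a stronger inhibitor, a higher number a weaker inhibitor), the highest number among the three measured compounds; compound 2 `O=C(O)C#Cc1ccc(Cn2cccn2)cc1OCCc1ccc2ccccc2c1` gives 1200 nM and compound 1 `O=C(O)/C=C/c1ccc(Cn2cccn2)cc1OCCc1ccc2ccccc2c1` gives 73 nM. The steps of a 36-fold higher number from compound 1 to compound 3 (1.55 log units; beyond the scatter) and a 2.2-fold higher number from compound 2 to compound 3 (0.34 log units; beyond the scatter) show how strongly the acid-bearing side chain shapes the result. Compound 4 `O=C(O)CCCc1ccc(Cn2cccn2)cc1OCCc1ccc2ccccc2c1` carries 3-carboxypropyl in place of carboxymethoxy on an aromatic carbon. Within the data shown here, no measured step tests a saturated chain of this kind, so the direction rests only on the acid-bearing chains of compound 1 and compound 2, both of which give lower numbers than compound 3. Compound 4 is therefore expected to give a lower number in this assay, a 4.3-fold lower number from compound 3 to compound 4 (0.64 log units; beyond the scatter), an estimated 600 nM with a range from 120 nM to 3000 nM.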

Compound 4, half-maximal inhibitory concentration: 460 nM
Estimate against measurement, compound 4: 1.3-fold (0.12 log units) above, within the range that was stated.
By their numbers in this assay, from the lowest: compound 1; then compound 4; then compound 2; then compound 3.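

In this assay, a saturated chain at this aromatic carbon proves compatible with a lower number than carboxymethoxy gives, with a 5.7-fold lower number from compound 3 to compound 4 (0.75 log units; beyond the scatter), and also than 2-carboxyethynyl gives, with a 2.6-fold lower number from compound 2 to compound 4 (0.42 log units; beyond the scatter). An unsaturated link is thus not needed to improve on those two chains, yet the 2-carboxyethenyl chain still keeps the lead, with a 6.3-fold higher number from compound 1 to compound 4 (0.80 log units; beyond the scatter). Nothing available here accounts for this order. Open, going by these compounds, is how a 2-carboxyethyl chain or a longer carboxylic chain would compare, and whether a tetrazole or an amide could stand in for the carboxylic acid at this position.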